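The source may report more compounds than this note shows. Statements on the series, on what has been measured and on what is new or still open speak of the compounds shown alone.

Compound 1 `Nc1nc(Cl)c2ncn(Cc3ccccc3CCl)c2n1` gives 17000 nM in a functional assay on 786-0 cells (Homo sapiens) for cytotoxicity, read by sulforhodamine B assay, with a stated time of 48 h; on this read-out higher numbers stand for weaker inhibition of growth and lower numbers for stronger inhibition of growth. Compound 2 `ClCc1ccccc1Cn1cnc2nc(Cl)nc(Cl)c21` gives 2630 nM. Compound 3 `Nc1nc(Cl)c2ncn(Cc3cccc(CCl)c3)c2n1` gives 6600 nM.

Among the compounds with values here, of the three numbers measured so far, compound 1 stands highest, meaning it is the weakest of the three at holding back growth of these cells. Compound 3 is its nearest neighbour, with a number lower by a margin that lies beyond the scatter of repeated measurements, and compound 2 is the furthest, lower by a still wider margin.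

The step to compound 4 `ClCc1ccccc1Cn1cnc2c(Cl)ncnc21` changes one thing on the shared core of compound 1: hydrogen in place of amino on an aromatic carbon. The change lands on an aromatic carbon of a six-membered aromatic ring with two nitrogen, between two ring nitrogen atoms, and the rest of the molecule is left untouched. Within the data shown here, no step between two measured compounds isolates this change, so its effect is not known directly. What the measured pairs show is that compound 2, which carries no amino group, gives a lower number than compound 1, and that both compounds with an amino group give the higher numbers. On this basis a modest drop in this assay is expected for compound 4, though a change within the scatter cannot be ruled out. The step of a 2.1-fold lower number from compound 1 to compound 4 (0.33 log units; beyond the scatter) is the size of change expected here. Compound 4 is estimated at 8000 nM, with a likely range from 2500 nM to 25000 nM.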

Compound 4, concentration for 50% growth inhibition: 17800 nM
Compound 4: middle estimate off by 2.2-fold (0.35 log units), on the low side; the range from low to high includes it.
By their numbers in this assay, from the lowest: compound 2; then compound 3; then compounds 1 and 4 (each within the scatter of the next).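

A step of a 1.0-fold higher number from compound 1 to compound 4 (0.02 log units; within the scatter) in this assay means that hydrogen in place of amino on this aromatic carbon, between two ring nitrogen atoms, leaves growth inhibition where it was. The amino group on the shared core of compound 1 can therefore go without any visible loss or gain here, and compound 4 goes against the earlier impression that compounds without amino give the lower numbers. Compound 2 differs from compound 4 in more than one place, so its lower number cannot be tied to this carbon, and no further measurement helps to explain the flat step.

Still open, going by these compounds, is whether a different group on this carbon, such as methyl or methoxy, would move the number. Also open, on these data alone, is whether the same swap would read the same way on compound 3.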